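Allyl-substituted series: cytotoxicity on Huh-7 cells

This account rests on a few compounds, and the source may have more. Where it says the series, first, only, none or still open, it means among the compounds named here.

Measured so far:
compound 1 `C=CCn1c(=O)/c(=C\c2ccc(Cl)c(Cl)c2)[nH]c(=O)/c1=C\c1ccccc1` — "not active" (no number reported)
compound 2 `C=CCn1c(=O)/c(=C\c2cccc(F)c2)[nH]c(=O)/c1=C\c1ccccc1OC` — 27200 nM
compound 3 `COc1ccccc1/C=c1/[nH]c(=O)/c(=C\c2nc[nH]c2C(C)(C)C)[nH]c1=O` — 90 nM

In a functional assay on Huh-7 cells (Homo sapiens) for cytotoxicity, read by CCK-8 assay, with a stated time of 72 h (a higher number here means a weaker inhibitor, a lower number a stronger inhibitor), compound 1 gives "not active" (no number reported), so no number is available for it. Compound 2 gives 27200 nM, which is the highest of the two numbers reported here. Among the measured compounds shown here, compound 3, which carries no allyl group on its core, gives 90 nM, a far lower number than compound 2; no single-change step connects these two compounds, so the gap between them speaks only for the pair as a whole.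

Compound 4 `C=CCn1c(=O)/c(=C\c2ccccc2Cl)[nH]c(=O)/c1=C\c1ccccc1OC` is the next entry to be measured in this assay. It differs from compound 2 in one place: 2-chlorophenyl in place of 3-fluorophenyl on a double-bonded chain carbon bound to an aromatic carbon. For the measured compounds named here, no measured step of this kind exists in the set, so the size of the effect is uncertain. Compound 1, the other allyl-bearing compound with a chlorine-substituted phenyl, is without activity, which argues against a large gain. The expected step of a 1.3-fold higher number from compound 2 to compound 4 (0.11 log units; within the scatter) is therefore small and, if anything, upward. Compound 4 is estimated at 35000 nM, with a range from 10000 nM to 120000 nM.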

Compound 4, half-maximal inhibitory concentration: 6400 nM
For compound 4 the middle estimate is 5.5-fold (0.74 log units) above the measured one; the whole stated range lies above it.
By their numbers in this assay, from the lowest: compound 3; then compound 4; then compound 2.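

In this assay, among the compounds shown here, the exchange of 3-fluorophenyl for 2-chlorophenyl gives a 4.3-fold lower number from compound 2 to compound 4 (0.63 log units; beyond the scatter) and is the only step that can be read at a single place. It shows that the number responds to the aromatic group on a double-bonded chain carbon bound to an aromatic carbon, even though the rest of the structure stays the same and the step stands beyond the usual scatter, though only modestly. The computed counts for the two groups match in heavy atoms, hydrogen-bond donors, hydrogen-bond acceptors and net charge, and no measurement on hand bears on why the number falls.

The step changes the halogen and its position on the phenyl ring together, so the compounds shown cannot say how much of the shift belongs to chlorine in place of fluorine and how much to the different placement. Also open, going by these compounds, is how this place would respond to a group of a different kind, such as an amine or a carboxylic acid on the phenyl ring, since only halogen-bearing phenyl groups are compared here.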